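The source may hold more compounds than are shown below. What is called first, only, known or untested is meant among the compounds shown, and "the series" means these compounds.

Measured so far:
compound 1 `Cc1cc(NC(=O)Cn2nnc(-c3cccc(F)c3)n2)n(C2CCCCC2)n1`: 81 nM
compound 2 `Cc1cc(NC(=O)Cn2nnc(-c3ccccc3F)n2)n(C2CCCCC2)n1`: 187 nM

In an assay on HEK293 cells for activation of Kir3.1/Kir3.2 (Homo sapiens), read by thallium flux (a lower number here means that less compound is needed, a higher number that more compound is needed for the effect), compound 2 gives 187 nM, the higher of the two numbers, and compound 1 gives 81 nM. Within the data shown here, the only measured step is a 2.3-fold higher number from compound 1 to compound 2 (0.36 log units; beyond the scatter), a move of the fluorine within the same ring. Compound 3 `Cc1cc(NC(=O)Cn2nnc(-c3ccnc(F)c3)n2)n(C2CCCCC2)n1` changes the ring itself: 2-fluoropyridin-4-yl in place of 2-fluorophenyl on an aromatic carbon. Among the measured compounds shown here, no measured step touches a ring nitrogen, so the fluorine-shift step bears only loosely on it. The expected step is a 1.1-fold higher number from compound 2 to compound 3 (0.05 log units; within the scatter), probably not beyond the scatter. Compound 3 is estimated at 210 nM, within 70 nM to 650 nM.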

Compound 3, half-maximal effective concentration: 441 nM
Compound 3: the middle estimate sits 2.1-fold (0.32 log units) below what was measured; measured number inside the range.
By their numbers in this assay, from the lowest: compound 1; then compound 2; then compound 3.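

In this assay the group on the aromatic carbon of the five-membered aromatic ring with 4 nitrogen responds to a change of ring atom as well as to a shift of fluorine: 2-fluoropyridin-4-yl in place of 2-fluorophenyl gives a 2.4-fold higher number from compound 2 to compound 3 (0.37 log units; beyond the scatter) with the fluorine still on the ring. Set against 3-fluorophenyl, the same pyridine group gives a 5.4-fold higher number from compound 1 to compound 3 (0.74 log units; beyond the scatter) and this is the largest step among the three compounds. Nothing available gives a reason for either step.

Open, on these data alone, is whether a ring nitrogen has the same effect in a pyridine carrying fluorine in another place. Also open, as far as these compounds go, is how an unsubstituted phenyl, a chlorophenyl or a methoxyphenyl group would rank against these three.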